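From neopentyl to cyclohexyl on a pyridin-3-yl compound

The source may hold more compounds than are shown below. What is called first, only, known or untested is meant among the compounds shown, and "the series" means these compounds.

In a functional assay for inhibition, with Rattus norvegicus as the target (a lower number here means a stronger inhibitor, a higher number a weaker inhibitor), compound 1 `CC(C)(C)CN/C(=C\[N+](=O)[O-])Nc1ccncc1` gives 10000 nM and compound 2 `CC(C)(C)CN/C(=C\[N+](=O)[O-])Nc1cccnc1` gives 1000 nM, the lower of the two numbers. Within the data shown here, the one measured step, a 10-fold lower number from compound 1 to compound 2 (1.00 log units; beyond the scatter), goes with pyridin-3-yl in place of pyridin-4-yl on an amine nitrogen.

Compound 3 `O=[N+]([O-])/C=C(/Nc1cccnc1)NC1CCCCC1` keeps the pyridin-3-yl group of compound 2 and changes a different group: cyclohexyl in place of neopentyl on an amine nitrogen. In words, cyclohexyl stands in place of neopentyl on an amine nitrogen. Among the measured compounds shown here, no measured step covers this kind of change. For the measured compounds named here, the earlier step shows only that a single change can move the number in this small set. Neither group carries hydrogen-bond donors, acceptors or a net charge, so no shift beyond the scatter is the best guess in this assay, though with little evidence behind it. The expected step is no change at the digits printed from compound 2 to compound 3 (within the scatter). For compound 3 the estimated value is 1000 nM, with an expected range of 300 nM to 3500 nM.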

Compound 3, half-maximal inhibitory concentration: 3160 nM
For compound 3 the middle estimate is 3.2-fold (0.50 log units) below the measured one; low and high end bracket the measured number.
By their numbers in this assay, from the lowest: compound 2; then compound 3; then compound 1.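

In this assay the amine nitrogen carrying the neopentyl group proves sensitive to what sits on it: cyclohexyl in its place gives a 3.2-fold higher number from compound 2 to compound 3 (0.50 log units; beyond the scatter), a weaker inhibitor. The number therefore responds to a change at this second place as well as to the change in the pyridine attachment, even though neither group carries hydrogen-bond donors, acceptors or a net charge. Nothing measured here offers a reason for this shift.

From the compounds shown here alone, only neopentyl and cyclohexyl can be compared at this nitrogen, so it remains open whether a cyclopentyl ring, a straight butyl chain or a chain ending in an amine would land nearer compound 2 or further from it. Also open, going by these compounds, is whether the same swap would give a similar step with the pyridin-4-yl group of compound 1.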